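This account rests on a few compounds, and the source may have more. Where it says the series, first, only, none or still open, it means among the compounds named here.

Measured so far, in a functional assay for inhibition, with Homo sapiens as the target; a higher number here means a weaker inhibitor, a lower number a stronger inhibitor:
compound 1, `Cc1nc(-c2ccccc2)n2c(S)nncc12` — at the limit of the assay, > 48000 nM
compound 2, `CCCc1nc(C)c2c(C)nnc(SC)n12` — at the limit of the assay, > 48000 nM
compound 3, `Cc1nc(CC(C)(C)C)n2c(O)nncc12` — at the limit of the assay, > 48000 nM

Compound 3 stands where the whole series stands so far: at the limit of > 48000 nM in this assay, at which 3 of the 3 values shown sit. Going by the values given here, no number has been reached for any of the three, so no step between measured compounds can be read, and nothing separates compound 3 from compound 1 or compound 2 on these values.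

Compound 4, `CCCc1nc(C)c2cnnc(O)n12`, differs from compound 3 by ethyl in place of tert-butyl on a saturated chain carbon bound to an aromatic carbon. Cut one bond further out, the same difference reads neopentyl to propyl; the rest of the core of compound 3 is kept.

With compound 3 sitting at the limit, the series gives no ground to expect a step that clears the scatter in this assay, in either direction. In this assay compound 4 is expected at 60000 nM, within 20000 nM to 200000 nM. The expected step is a step that the limit leaves unreadable from compound 3 to compound 4, meaning no change beyond the scatter, with a limit rather than a number the most likely outcome.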

Compound 4, half-maximal inhibitory concentration: 56800 nM
Estimate against measurement, compound 4: 1.1-fold (0.02 log units) above, and the stated range covers the measured number.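

In this assay, going by these compounds alone, no step from compound 3 to compound 4 can be read, since compound 3 rests on a limit: the limit of > 48000 nM in this assay, at which 3 of the 4 values shown sit.

The compounds shown leave open whether any single change on the shared core moves inhibition beyond the scatter, with only compound 4 carrying a number rather than a limit.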